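The source may report more compounds than this note shows. Statements on the series, on what has been measured and on what is new or still open speak of the compounds shown alone.

Among the compounds with values here, the set holds no pair of measured compounds that differ in a single place, so each entry is taken on its own. Compound 1 `Fc1ccc(-c2ccc(-n3cc(-c4ccccc4)nn3)cc2)cn1` carries no result in a functional assay on MCF7 cells (Homo sapiens) for inhibition, read by resazurin assay, with a stated time of 72 h (a lower number here means a stronger inhibitor, a higher number a weaker inhibitor), recorded as "not determined" (no result reported). Compound 2 `Clc1ccccc1-c1ccc(-n2cc(-c3ccccc3)nn2)cc1` reaches only a limit of this assay, < 50000 nM, the point described by the limit of < 50000 nM in this assay, at which 1 of the 3 values shown sits. Compound 3 `Clc1ccccc1-c1ccn2ncnc2n1` likewise gives only a limit in this assay, > 100000 nM, which is the limit of > 100000 nM in this assay, at which 1 of the 3 values shown sits. Compound 3 thus stands without a single number, among entries that are themselves a limit or absent. Compound 4 `c1ccc(-c2ccn3ncnc3n2)cc1` differs from it by hydrogen in place of chloro on an aromatic carbon. Within the data shown here, with no measured step to guide it, the change is expected to move the value by nothing beyond the scatter. Compound 4 is therefore estimated at 150000 nM in this assay, between 40000 nM and 600000 nM. The expected step is a step that the limit leaves unreadable from compound 3 to compound 4.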

Compound 4, half-maximal inhibitory concentration: 3910 nM
For compound 4 the middle estimate is 38-fold (1.58 log units) above the measured one, outside the stated range (below it).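

In this assay, within the data shown here, the step of an at least 25-fold lower number from compound 3 to compound 4 (1.40 log units; beyond the scatter) shows that this aromatic carbon is not a silent position: with hydrogen in place of chloro, the shared core gives a single measured number for the first time. From the compounds shown here alone, compound 3 gives only a limit, > 100000 nM, so the full size of the step stays unknown. Nothing measured here accounts for the step. The compounds shown leave open whether fluoro, methoxy or an amine on this carbon would match hydrogen or chloro, and whether the same change would act alike on the core of compound 2.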